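Swapping Chlorine for Methyl on the Pyridine Ether

The compounds below may be only part of what the source reports. "The series", "measured", "known", "first", "only" and "open" are said of these compounds alone.

Three measured compounds share one core and differ only in the aryl group attached through an ether oxygen. In a physicochemical assay for lipophilicity, read by LC-MS, in phosphate buffer, measured as octanol-water partition, with a stated time of 30 min, at pH 7.4, tested at 200 mM (a lower number here means a more polar compound, a higher number a more lipophilic compound), compound 1 `Cc1ccc(Oc2ccc3nc(COc4cccc(C(=O)O)c4)n(C)c3n2)cc1C` gives 2.2, compound 2 `Cn1c(COc2cccc(C(=O)O)c2)nc2ccc(Oc3ccc4c(c3)OCC4)nc21` gives 1.4, and compound 3 `Cn1c(COc2cccc(C(=O)O)c2)nc2ccc(Oc3cccc(Cl)n3)cc21` gives 1.2. Compound 3 stands lowest of the three numbers; its value lies within the scatter of compound 2 and beyond the scatter of compound 1. Within the data shown here, the only step between measured compounds that differ in one place is a number 0.80 log units lower from compound 1 to compound 2 (beyond the scatter), which concerns a different aryl group and does not bear directly on the change considered here.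

Compound 4 `Cc1cccnc1Oc1ccc2nc(COc3cccc(C(=O)O)c3)n(C)c2c1` is compound 3 with 3-methylpyridin-2-yl in place of 6-chloropyridin-2-yl on an oxygen on an aromatic ring. Among the measured compounds shown here, no measured pair shows a chlorine exchanged for a methyl group on this ring, so there is no measured step of the same kind to lean on, and the expectation rests on the counted similarity of the two groups, which are of equal heavy-atom count with one hydrogen-bond acceptor each. Compound 4 is therefore expected to lie close to its parent, and the expected step is a number 0.10 log units lower from compound 3 to compound 4 (within the scatter), within the scatter. The estimate for compound 4 in this assay is 1.1, ranging from 0.6 to 1.6.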

Compound 4, distribution coefficient: 0.9
Compound 4: middle estimate off by 0.20 log units, on the high side, and the stated range covers the measured number.
By their numbers in this assay, from the lowest: compounds 4, 3 and 2 (each within the scatter of the next, the first and the last beyond it); then compound 1.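

In this assay, among these compounds, the first measured exchange at this place gives a number 0.30 log units lower from compound 3 to compound 4 (within the scatter), so on an oxygen on an aromatic ring, 3-methylpyridin-2-yl and 6-chloropyridin-2-yl cannot be told apart by this read-out on the shared core. Among the compounds shown here, this is a single pair, yet it offers something the earlier compounds could not: a direct comparison of two pyridine ethers that differ in one place and match in the heavy-atom and hydrogen-bond counts. No measurement at hand gives a reason for this result or shows what either group contributes to the number.

The exchange alters two things at once, the group on the pyridine and the number that marks it in the name, so the compounds shown leave open how much each matters, a question that 6-methylpyridin-2-yl or 3-chloropyridin-2-yl on the same core could help separate. They also leave open how far the number would move with an unsubstituted pyridin-2-yl, or with an amine or a methoxy group in place of the chlorine or the methyl.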